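The source may report more compounds than this note shows. Statements on the series, on what has been measured and on what is new or still open speak of the compounds shown alone.

Working notes on the series, all read in a functional assay on HeLa cells (Homo sapiens) for inhibition, read by sulforhodamine B assay; on this read-out higher numbers stand for weaker inhibition and lower numbers for stronger inhibition. Compound 1 `O=C1C(Nc2ccccc2)=CC(=O)c2c1nc1n2[C@H]2OC[C@@H](O)[C@H]2OC1` returns only a limit, > 8000 nM. Compound 2 `O=C1C(NC2CCCC2)=CC(=O)c2c1nc1n2[C@H]2OC[C@@H](O)[C@H]2OC1` also returns only a limit, > 16000 nM. Compound 3 `O=C1C=C(NC2CCCCC2)C(=O)c2c1nc1n2[C@H]2OC[C@@H](O)[C@H]2OC1` returns only a limit as well, > 16000 nM. Compound 2 thus has no numerical potency and sits at the limit of > 16000 nM in this assay, at which 2 of the 3 values shown sit, alongside compound 3. Compound 1 sits at the limit of > 8000 nM in this assay, at which 1 of the 3 values shown sits.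

The next case is compound 4 `O=C1C(N2CCCCC2)=CC(=O)c2c1nc1n2[C@H]2OC[C@@H](O)[C@H]2OC1`, which has piperidin-1-yl in place of cyclopentylamino on a double-bonded ring carbon. The two compounds have the same atoms, joined differently.

Among the compounds with values here, the only measured step that bears on this change is a step that the two limits leave unreadable from compound 1 to compound 2, and it supplies no size to carry over. Within the data shown here, it involves a different group on the amine nitrogen, and the series so far contains no measured number. On that basis, no step beyond the scatter is expected in this assay, and no direction can be assigned. The expected step is a step that the limit leaves unreadable from compound 2 to compound 4. For compound 4, the estimated value is 20000 nM, with an expected range of 8000 nM to 50000 nM, and the assay is expected most likely to report only a limit again.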

Compound 4, half-maximal inhibitory concentration: > 16000 nM
Compound 4 ended at the assay's limit (the forecaster's own chance of this, stated with the estimate: 80%); the middle value does not contradict the limit.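

In this assay compound 4 gives > 16000 nM, which is a limit and not a number. Compound 1 and compound 2 also stand only as limits, so the steps joining them to compound 4 cannot be read. The compounds shown leave open how anilino, cyclopentylamino and piperidin-1-yl on the shared core rank against one another in this assay.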